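A Methoxy Group on a Weak Growth Inhibitor

A few compounds are considered here, and "the series" means these few. Any claim that something is new, unique, unknown or untested is made for them only; others in the source may bear on it.

In a functional assay on OVCAR-3 cells (Homo sapiens) for inhibition, read by sulforhodamine B assay, with a stated time of 48 h (on this read-out lower numbers stand for stronger inhibition of growth and higher numbers for weaker inhibition of growth), compound 2 `CC(C)(C)NCc1c(C(=O)O)nn(-c2ccc(Cl)cc2)c1-c1ccc(F)cc1` gives 116000 nM, while compound 3 `CC(C)(C)NCc1c(C(=O)O)nn(-c2ccc(Cl)cc2)c1-c1ccccc1` gives 653000 nM, the higher of these two numbers. Compound 1 `COc1ccc(-c2c(CNC(C)(C)C)c(C(=O)O)nn2-c2ccccc2)cc1` gives only > 659000 nM, which is a limit of the assay.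

Compound 4 `COc1ccc(-c2c(CNC(C)(C)C)c(C(=O)O)nn2-c2ccc(Cl)cc2)cc1` differs from compound 3 by methoxy in place of hydrogen on an aromatic carbon, with methoxy in place of hydrogen on an aromatic carbon. Going by the values given here, the one measured step is a 5.6-fold higher number from compound 2 to compound 3 (0.75 log units; beyond the scatter), a modest change beyond the scatter, in which hydrogen replaces fluoro on an aromatic carbon. Compound 1 also carries the 4-methoxyphenyl group, so caution is needed. The expected change is a modest move toward a lower number, a 2.2-fold lower number from compound 3 to compound 4 (0.34 log units; beyond the scatter). Compound 4 is estimated at 300000 nM, with an expected range of 90000 nM to 800000 nM.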

Compound 4, concentration for 50% growth inhibition: 121000 nM
For compound 4 the middle estimate is 2.5-fold (0.39 log units) above the measured one, and the stated range covers the measured number.
By their numbers in this assay, from the lowest: compounds 2 and 4 (each within the scatter of the next); then compound 3. At a limit, above all of these: compound 1.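

In this assay, methoxy on this aromatic carbon, para to a large group, gives a 5.4-fold lower number from compound 3 to compound 4 (0.73 log units; beyond the scatter), so a substituent here can matter, much as fluoro does. Methoxy and fluoro cannot be told apart at this place, with a 1.0-fold higher number from compound 2 to compound 4 (0.02 log units; within the scatter). Chloro in place of hydrogen elsewhere gives an at least 5.4-fold lower number from compound 1 to compound 4 (0.73 log units; beyond the scatter), but this step is only a bound, since compound 1 stands at a limit: the limit of > 659000 nM in this assay, at which 1 of the 4 values shown sits.

On these data alone, whether an amine or an ethoxy group on this carbon would lower the number further remains open.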